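The source may hold more compounds than are shown below. What is called first, only, known or untested is meant among the compounds shown, and "the series" means these compounds.

In a toxicity assay on J774.A1 cells (Mus musculus) for cytotoxicity, read by MTT assay (on this read-out higher numbers stand for weaker inhibition and lower numbers for stronger inhibition), compound 2 `CCOC(=O)NC(=O)c1ccsc1NC(=O)c1ccc(S(=O)(=O)N2CCCC2)cc1` gives > 64 ug/mL. That figure is a limit of the assay and not a number. Among the compounds with values here, the only exact reading available comes from compound 1 `COC(=O)NC(=O)c1ccsc1NC(=O)c1ccc(S(=O)(=O)N2CCC(OC)CC2)cc1`, which gives 54.9 ug/mL in this assay. Within the data shown here, the whole picture is thin, with the limit of > 64 ug/mL in this assay, at which 1 of the 2 values shown sits, and no two measured compounds differ in one place only, so no measured step can serve as a guide.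

The next compound to be tested is compound 3 `CCOC(=O)NC(=O)c1ccsc1NC(=O)c1ccc(S(=O)(=O)N2CCCCC2)cc1`. It departs from compound 2 by one change: piperidin-1-yl in place of pyrrolidin-1-yl on a sulfonyl sulfur. In words, piperidin-1-yl stands in place of pyrrolidin-1-yl on a sulfonyl sulfur, and the rest of the molecule stays the same.

Among the measured compounds shown here, with no measured step to lean on, the expectation in this assay is for no shift beyond the usual scatter, in either direction. The estimated step of an at least 1.0-fold lower number from compound 2 to compound 3 (0.02 log units; that floor lies within the scatter) is therefore a small one. The assay may also report only a limit for the new compound. Compound 3 is expected to read about 60 ug/mL, with an estimated range of 30 ug/mL to 120 ug/mL.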

Compound 3, half-maximal inhibitory concentration: 34.3 ug/mL
Compound 3: middle estimate off by 1.7-fold (0.24 log units), on the high side; the measured number falls inside the stated range.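

With compound 3, the position on the sulfonyl sulfur yields its first step that can be read in this assay: piperidin-1-yl in place of pyrrolidin-1-yl gives an at least 1.8-fold lower number from compound 2 to compound 3 (0.27 log units; that floor lies within the scatter). Compound 2 reads > 64 ug/mL, which is a limit of the assay and not a number, whereas compound 3 provides an exact reading for this ring at this position. The true step may be larger than its floor, but on the printed figures this single ring change cannot be called a shift beyond the scatter, and its size remains unfixed because one end of the step is only a limit: the limit of > 64 ug/mL in this assay, at which 1 of the 3 values shown sits.

The compounds shown leave open what other groups on the same sulfonyl sulfur would give, such as the larger ring azepan-1-yl, morpholin-4-yl with its second ring hetero atom, or the open-chain diethylamino. They also leave open whether replacing pyrrolidin-1-yl with piperidin-1-yl would give a similar step with a methyl carbamate in place of the ethyl carbamate that compound 2 and compound 3 share.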